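Swapping a pyridine for a pyrazole on a thiophene

This account rests on a few compounds, and the source may have more. Where it says the series, first, only, none or still open, it means among the compounds named here.

Measured compounds:
Compound 1, `CC(C)(C)Cc1c(-c2cccnc2)sc(N)c1C(=O)c1ccc(Cl)cc1`, gives 1% in an assay on CHO cells for displacement of a labelled ligand from adenosine receptor A1 (Homo sapiens), read by scintillation counting, tested at 10 uM; a lower number here means less inhibition, a higher number more inhibition at the concentration tested (going by the name of the read-out).
Compound 2, `CC(C)(C)Cc1c(-c2ccccc2)sc(N)c1C(=O)c1ccc(Cl)c(Cl)c1`, gives 1% in this assay.

Both measured compounds share the same core and show almost no displacement of the labelled ligand. Compound 1 stands level with compound 2 at the digits reported; the two values lie within the scatter of each other, so nothing separates them. No comparison of single changes between measured compounds is available. Compound 1 and compound 2 differ from each other in two places at once.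

Compound 3, `CC(C)(C)Cc1c(-c2cn[nH]c2)sc(N)c1C(=O)c1ccc(Cl)cc1`, has not yet been measured in this assay. Relative to compound 1 the change is 1H-pyrazol-4-yl in place of pyridin-3-yl on an aromatic carbon. The new group is a 1H-pyrazol-4-yl with one hydrogen-bond donor and one acceptor, in place of a pyridin-3-yl with one acceptor and no donor.

Among the measured compounds shown here, with both measured compounds near zero, the only guide is that neither the pyridin-3-yl nor the phenyl variant shows measurable inhibition. Compound 3 is therefore expected to stay in that range, with a step of a number 2 percentage points higher from compound 1 to compound 3 (within the scatter) that is no larger than the scatter. The estimate for compound 3 is 3%, within -8% to 15%.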

Compound 3, a percentage reported as inhibition, at one concentration (the size of the read-out at that concentration, not a potency): 1%
For compound 3 the middle estimate is 2 percentage points above the measured one; measured number inside the range.
By their numbers in this assay, from the lowest: compounds 1, 2 and 3 (each within the scatter of the next).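

In this assay, putting 1H-pyrazol-4-yl in place of pyridin-3-yl on the aromatic carbon next to the ring sulfur gives no change at the digits printed from compound 1 to compound 3 (within the scatter). Among the compounds shown here, this is the first comparison at this position that differs in one place only: a five-membered aromatic ring with a hydrogen-bond donor enters where a six-membered aromatic ring without one stood, and the read-out remains close to zero, so adding this donor does not bring measurable displacement of the labelled ligand at the concentration tested. No measurement at hand offers an explanation for this result.

Since every value shown lies near zero, the compounds cannot show whether this position matters for displacement at all, and a read-out this low could not reveal any change that would reduce it further. As far as these compounds go, it remains open whether a carboxylic acid or a morpholine at this position, or a shorter chain such as ethyl in place of the neopentyl group, would lift the read-out clear of the scatter.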